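Removing a methoxy from compound 1: what the single precedent says

The source may hold more compounds than are shown below. What is called first, only, known or untested is meant among the compounds shown, and "the series" means these compounds.

Of the compounds shown here, three have been measured so far. Compound 1 `COc1ccc(-c2[nH]c3ccccc3c2/C=C(\C#N)S(=O)(=O)c2ccccc2)cc1` gives 344 nM in a functional assay on SK-MEL-5 cells (Homo sapiens) for inhibition, read by sulforhodamine B assay, with a stated time of 48 h (on this read-out higher numbers stand for weaker inhibition of growth and lower numbers for stronger inhibition of growth), the second highest of the three numbers. Compound 3 `COc1ccc(-c2[nH]c3ccc(OC)cc3c2C=C(C#N)C#N)cc1` sits nearest at 324 nM, within the scatter, while compound 2 `COc1ccc2[nH]c(-c3ccccc3)c(C=C(C#N)C#N)c2c1` is furthest at 2900 nM, beyond the scatter. Compound 4 `N#C/C(=C\c1c(-c2ccccc2)[nH]c2ccccc12)S(=O)(=O)c1ccccc1` carries hydrogen in place of methoxy on an aromatic carbon relative to compound 1, turning 4-methoxyphenyl into phenyl. Going by the values given here, one measured step bears on this: a 9.0-fold lower number from compound 2 to compound 3 (0.95 log units; beyond the scatter), which added the same methoxy in reverse. Taking that step backwards, the number for compound 4 is expected to rise by a 5.8-fold higher number from compound 1 to compound 4 (0.76 log units; beyond the scatter) in this assay. Compound 4 is therefore estimated at 2000 nM, with a range from 600 nM to 7000 nM.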

Compound 4, concentration for 50% growth inhibition: 1820 nM
Compound 4: the middle estimate sits 1.1-fold (0.04 log units) above what was measured; the measured number falls inside the stated range.
By their numbers in this assay, from the lowest: compounds 3 and 1 (each within the scatter of the next); then compounds 4 and 2 (each within the scatter of the next).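

Replacing the methoxy of the 4-methoxyphenyl group with hydrogen also weakens growth inhibition on a second core, with a 5.3-fold higher number from compound 1 to compound 4 (0.72 log units; beyond the scatter) in this assay. Until now, this change had been read on one core only. It now has a similar size on both, so the methoxy at this place matters on more than one core: the same change on two cores in this assay, a 9.0-fold lower number (0.95 log units; beyond the scatter) from compound 2 to compound 3 and a 5.3-fold lower number (0.72 log units; beyond the scatter) from compound 4 to compound 1, 1.7-fold (0.23 log units) apart, within the scatter of two such steps.

Only methoxy and hydrogen appear at this place in the compounds shown. From the compounds shown here alone, how a hydroxyl, an amine or a longer chain such as ethoxy would read there remains open.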